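A chloro group added to a compound at the limit

This account rests on a few compounds, and the source may have more. Where it says the series, first, only, none or still open, it means among the compounds named here.

Compound 1 `O=S(=O)(Nc1ccc(-c2nc3ccccc3o2)cc1)c1ccc(Cl)s1`: > 100000 nM, a limit
Compound 2 `O=S(=O)(Nc1ccc(-c2nc3ccccc3o2)cc1)c1ccccc1F`: > 100000 nM, a limit
Compound 3 `COc1ccccc1S(=O)(=O)Nc1ccc(-c2nc3ccccc3o2)cc1`: > 100000 nM, a limit

All three compounds were tested in an ADME assay on HEK293 cells (Homo sapiens) for cytotoxicity, read by resazurin assay, with a stated time of 48 h (on this read-out higher numbers stand for lower toxicity in this test and lower numbers for higher toxicity in this test), and none gave a number: the limit of > 100000 nM in this assay, at which 3 of the 3 values shown sit. Compound 3 therefore stands only at its limit of > 100000 nM.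

Compound 4 `COc1ccc(Cl)cc1S(=O)(=O)Nc1ccc(-c2nc3ccccc3o2)cc1` differs from compound 3 in one place: chloro in place of hydrogen on an aromatic carbon. The chloro replaces a hydrogen para to a methoxy group, turning 2-methoxyphenyl into 5-chloro-2-methoxyphenyl.

The measured steps bear on this change only loosely, and none has a readable size. They are a step that the two limits leave unreadable from compound 1 to compound 2, a step that the two limits leave unreadable from compound 1 to compound 3 and a step that the two limits leave unreadable from compound 2 to compound 3. Compound 1, whose 5-chlorothiophen-2-yl group also carries a chloro, sits at its limit of > 100000 nM. This gives no sign that a chloro lowers the reading, so no step beyond the scatter is expected in this assay, and no direction can be assigned.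

The expected outcome is a number no higher from compound 3 to compound 4 (the limit leaves the size open). Compound 4 is estimated at 100000 nM. The expected range for compound 4 runs from 40000 nM to 200000 nM, and the assay may well report only a limit again.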

Compound 4, half-maximal cytotoxic concentration: 75000 nM
Beside the measured number, compound 4's estimate is 1.3-fold (0.12 log units) above it, within the range that was stated.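

In this assay, within the data shown here, the 5-chloro-2-methoxyphenyl group gives the only reading in this set that is a number rather than a limit: the limit of > 100000 nM in this assay, at which 3 of the 4 values shown sit. At this place, on an aromatic carbon para to a methoxy group, chloro in place of hydrogen gives an at least 1.3-fold lower number from compound 3 to compound 4 (0.12 log units; that floor lies within the scatter), so the change cannot yet be told apart from repeat-to-repeat variation. Replacing the whole group on the sulfonyl sulfur tells the same story, with an at least 1.3-fold lower number from compound 2 to compound 4 (0.12 log units; that floor lies within the scatter) and an at least 1.3-fold lower number from compound 1 to compound 4 (0.12 log units; that floor lies within the scatter), and neither step shows more than that compound 4 falls within measurable range.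

As far as these compounds go, the steps among compound 1, compound 2 and compound 3 cannot be read, and the true size of all three new steps stays open because each one starts from a limit. The compounds shown also leave open whether a bromo, a methyl or an amine at this same place would give a number in this assay like that of compound 4, or a limit like that of compound 3.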